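Bromine Replacing Methyl on the Aryl Ring of Compound 1

The source may hold more compounds than are shown below. What is called first, only, known or untested is meant among the compounds shown, and "the series" means these compounds.

Compound 1 `CCC1=C(O)c2c(oc(-c3ccc(C)cc3)cc2=O)C(CC)(CC)C1=O` carries a methyl group on its pendant aromatic ring, and in a functional assay on KB cells (Homo sapiens) for antiproliferative activity, read by sulforhodamine B assay, with a stated time of 3 days (on this read-out higher numbers stand for an effect only at larger amounts of compound and lower numbers for an effect already at smaller amounts), compound 1 gives 39.2 uM. Compound 2 `CCC1=C(O)c2c(oc(-c3ccc(OC)cc3)cc2=O)C(CC)(CC)C1=O` gives 17.7 uM, and compound 3 `CCC1=C(O)c2c(oc(-c3ccc(OC(F)(F)F)cc3)cc2=O)C(CC)(CC)C1=O` gives 36.5 uM. Among the compounds with values here, compound 1 therefore stands highest of the three numbers, yet only the step to compound 2 is beyond the scatter: a 2.2-fold lower number from compound 1 to compound 2 (0.35 log units; beyond the scatter), whereas a 1.1-fold lower number from compound 1 to compound 3 (0.03 log units; within the scatter).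

Compound 4 `CCC1=C(O)c2c(oc(-c3ccc(Br)cc3)cc2=O)C(CC)(CC)C1=O` differs from compound 1 in one place: bromo in place of methyl on an aromatic carbon. Within the data shown here, no measured step involves bromine, so the two steps from compound 1 can only frame what a single change on this aromatic carbon does here: one modest step downward to compound 2, one step that stays within the scatter to compound 3. Neither gives reason to expect a large move in this assay, and it is expected that compound 4 sits close to compound 1, a 1.2-fold lower number from compound 1 to compound 4 (0.07 log units; within the scatter), within the scatter or slightly below it. Compound 4 is estimated at 33 uM, with a range from 14 uM to 80 uM.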

Compound 4, concentration for half-maximal effect: > 48.1 uM
Compound 4 gave a limit, no number (the forecaster's own chance of this, stated with the estimate: 5%); middle value at least 1.4-fold (0.16 log units) away from the limit.
By their numbers in this assay, from the lowest: compound 2; then compounds 3 and 1 (each within the scatter of the next). At a limit, above all of these: compound 4.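

Within the data shown here, compound 4 is the one compound of the four held at a limit, not a number: the limit of > 48.1 uM in this assay, at which 1 of the 4 values shown sits. Two of its steps settle no order, with an at least 1.2-fold higher number from compound 1 to compound 4 (0.08 log units; that floor lies within the scatter) and an at least 1.3-fold higher number from compound 3 to compound 4 (0.11 log units; that floor lies within the scatter), so bromo cannot be ranked against methyl or trifluoromethoxy on this aromatic carbon. The third step, an at least 2.7-fold higher number from compound 2 to compound 4 (0.43 log units; beyond the scatter), adds bromo to the groups that stand apart from methoxy here, so in this assay compound 2 now differs beyond the scatter from all three other compounds.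

On these data alone, how far the true value of compound 4 lies past its limit remains open. Also open, as far as these compounds go, is whether an amine, a hydroxyl or a longer ether such as ethoxy on this aromatic carbon would give a number as low as that of compound 2.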